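Alkoxy chain variation in a chloroquinoline cytotoxicity series

This account rests on a few compounds, and the source may have more. Where it says the series, first, only, none or still open, it means among the compounds named here.

Measured so far:
Compound 1, `CCCCCCCCOc1ccc2c(Cl)ccnc2c1`, gives 3640 nM.
Compound 2, `CCCCCCOc1ccc2c(Cl)ccnc2c1`, gives 2720 nM.

Both compounds were tested in a functional assay on RKO cells (Homo sapiens) for cytotoxicity, read by MTT assay, with a stated time of 48 h; on this read-out higher numbers stand for weaker inhibition and lower numbers for stronger inhibition. Compound 2 stands with the lowest of the two numbers, but its nearest neighbour is compound 1, and the step of a 1.3-fold lower number from compound 1 to compound 2 (0.13 log units; within the scatter) lies within the scatter, so the two cannot be told apart in this assay.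

Compound 3, `CC(C)Oc1ccc2c(Cl)ccnc2c1`, has not yet been measured. It differs from compound 2 in one place: isopropyl in place of hexyl on an oxygen on an aromatic ring. Within the data shown here, the only measured step that bears on this change is the one from compound 1 to compound 2, where one chain on the same oxygen was exchanged for another and the number moved by a 1.3-fold lower number from compound 1 to compound 2 (0.13 log units; within the scatter). Among the measured compounds shown here, that step is within the scatter, and no measured compound carries a branched group on this oxygen, so there is no evidence here for a step beyond the scatter in either direction.

On that basis compound 3 is expected to give about 3500 nM in this assay, with a range from 1200 nM to 12000 nM. This estimate corresponds to an expected step of a 1.3-fold higher number from compound 2 to compound 3 (0.11 log units; within the scatter).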

Compound 3, half-maximal inhibitory concentration: 2690 nM
The estimate for compound 3 lay 1.3-fold (0.11 log units) above the measured number; measured number inside the range.
By their numbers in this assay, from the lowest: compounds 3, 2 and 1 (each within the scatter of the next).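

In this assay, isopropyl in place of hexyl on an oxygen on an aromatic ring, a group of 3 heavy atoms for one of 6, gives a 1.0-fold lower number from compound 2 to compound 3 (0.00 log units; within the scatter), so the two compounds cannot be told apart. The earlier step compared only unbranched chains, whereas this one brings a branched group onto the same oxygen and still stays within the scatter. Among the three compounds shown, each within the scatter of the next, neither the branched group nor the difference in chain size gives a step that can be read, and no independent measurement here bears on this result.

The compounds shown leave open whether a smaller group on this oxygen, such as methyl, or a chain ending in an amine or a carboxylic acid would move the number beyond the scatter. They also leave open whether a ring on the oxygen, such as benzyl, would do so, and what part the chlorine on the shared core plays in the cytotoxicity seen here.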